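The source may report more compounds than this note shows. Statements on the series, on what has been measured and on what is new or still open speak of the compounds shown alone.

In an ADME assay (liver) for pharmacokinetics, with Liver microsome (Rattus norvegicus) as the target, read by LC-MS, using microsomes, tested at 2 uM (on this read-out lower numbers stand for slow clearance and higher numbers for fast clearance), compound 1 (`O=C(N[C@@H]1CCCC[C@H]1O)c1cnc(OC2CCCCC2)c(-c2ccc(Cl)cc2)c1`) gives 0.662 mL/min/kg, compound 2 (`O=C(N[C@@H]1CCCC[C@H]1O)c1cnc(OC2CCC2)c(-c2ccc(Cl)cc2)c1`) gives 0.21 mL/min/kg, and compound 3 (`O=C(N[C@@H]1CCCC[C@H]1O)c1cnc(OCc2ncccn2)c(-c2ccc(Cl)cc2)c1`) gives 0.012 mL/min/kg, the lowest of the three. Compound 4 (`O=C(N[C@@H]1CCCC[C@H]1O)c1cnc(CCC2CC2)c(-c2ccc(Cl)cc2)c1`) differs from compound 3 by 2-cyclopropylethyl in place of (pyrimidin-2-yl)methoxy on an aromatic carbon, with 2-cyclopropylethyl in place of (pyrimidin-2-yl)methoxy on an aromatic carbon. The nearest evidence is an 18-fold lower number from compound 2 to compound 3 (1.24 log units; beyond the scatter) and a 55-fold lower number from compound 1 to compound 3 (1.74 log units; beyond the scatter), both large, whereas a 3.2-fold lower number from compound 1 to compound 2 (0.50 log units; beyond the scatter) is modest. Going by the values given here, no measured step removes the oxygen, so these steps are only a partial guide. Read in reverse, they point to a large rise, and the expected step is a 25-fold higher number from compound 3 to compound 4 (1.40 log units; beyond the scatter). For compound 4 the estimated value is 0.3 mL/min/kg, within a range of 0.07 mL/min/kg to 1.2 mL/min/kg.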

Compound 4, clearance: 1.5 mL/min/kg
Beside the measured number, compound 4's estimate is 5.0-fold (0.70 log units) below it; measured number above the stated range.
By their numbers in this assay, from the lowest: compound 3; then compound 2; then compound 1; then compound 4.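

At this position in this assay the carbon-only 2-cyclopropylethyl group stands above every oxygen-linked group shown, with a 130-fold higher number from compound 3 to compound 4 (2.10 log units; beyond the scatter) and a 7.1-fold higher number from compound 2 to compound 4 (0.85 log units; beyond the scatter) and a 2.3-fold higher number from compound 1 to compound 4 (0.36 log units; beyond the scatter) as its steps. The range here therefore reaches higher than the three oxygen-linked groups showed, and even the cyclohexyloxy group of compound 1 lies under it. Nothing measured here accounts for this rise. The compounds shown leave open whether the rise belongs to the lost oxygen or to the chain itself. A 2-cyclopropylethoxy group or an amine link at this position would separate the two.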